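This account rests on a few compounds, and the source may have more. Where it says the series, first, only, none or still open, it means among the compounds named here.

Compound 1 `COc1ccccc1Nc1nc(-c2cccc(F)c2)nc2ccc(F)cc12`, compound 2 `Fc1cccc(Nc2nc(-c3cccc(F)c3)nc3ccc(F)cc23)c1` and compound 3 `Oc1ccc(Nc2nc(-c3cccc(F)c3)nc3ccc(F)cc23)cc1` share one core and differ only in the ring carried on the nitrogen; compound 4 `Oc1ccccc1Nc1nc(-c2cccc(F)c2)nc2ccc(F)cc12` is the fourth member and is not yet measured. Going by the values given here, in a functional assay on MCF7 cells (Homo sapiens) for cytotoxicity, read by MTT assay, with a stated time of 48 h (a higher number here means a weaker inhibitor, a lower number a stronger inhibitor), compound 2 gives 48700 nM, the only number among the three measured values. In this assay compound 1 reaches only the limit of the assay, > 50000 nM. In this assay compound 3 also reports only a limit, > 50000 nM. The steps between them are therefore bounded rather than read: an at least 1.0-fold lower number from compound 1 to compound 2 (0.01 log units; that floor lies within the scatter), an at least 1.0-fold higher number from compound 2 to compound 3 (0.01 log units; that floor lies within the scatter), and a step that the two limits leave unreadable from compound 1 to compound 3. All three values sit at or just under (the limit of > 50000 nM in this assay, at which 2 of the 3 values shown sit), so none of these steps rises beyond the scatter.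

Compound 4 differs from compound 2 in one place: 2-hydroxyphenyl in place of 3-fluorophenyl on a nitrogen on an aromatic ring. Among the compounds with values here, the steps that bear on it are the ring swaps already seen, an at least 1.0-fold higher number from compound 2 to compound 3 (0.01 log units; that floor lies within the scatter) and an at least 1.0-fold lower number from compound 1 to compound 2 (0.01 log units; that floor lies within the scatter), neither of which moved the read-out beyond the scatter. No step in the shown compounds leaves the region of the limit, so compound 4 is expected to stay there as well, with a 1.2-fold higher number from compound 2 to compound 4 (0.09 log units; within the scatter) as the expected step in this assay. Compound 4 is thus estimated at 60000 nM, within 30000 nM to 150000 nM, and most likely reported only as a limit.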

Compound 4, half-maximal inhibitory concentration: > 50000 nM
Compound 4 ended at the assay's limit; the forecaster's own chance of this, stated with the estimate: 70%; the middle value is on the limit's open side.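

In this assay, replacing 3-fluorophenyl with 2-hydroxyphenyl on the nitrogen brings in a ring that carries a hydrogen-bond donor and acceptor, and this gives an at least 1.0-fold higher number from compound 2 to compound 4 (0.01 log units; that floor lies within the scatter), a floor and not a measured size. The steps to compound 4 from compound 3 and from compound 1 cannot be read, as both ends of each are limits. The result adds 2-hydroxyphenyl to 4-hydroxyphenyl and 2-methoxyphenyl as rings on this nitrogen that leave the read-out in the region of the limit, with compound 2 the only compound given a number: the limit of > 50000 nM in this assay, at which 3 of the 4 values shown sit.

As far as these compounds go, whether any ring on this nitrogen can bring the read-out clearly away from that limit stays open, as does whether the place of the hydroxyl matters at all in this assay. A ring carrying an amine or a carboxylic acid, or a longer chain on the same nitrogen, would be needed to show whether this part of the molecule can change the read-out in this assay.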